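A few compounds are considered here, and "the series" means these few. Any claim that something is new, unique, unknown or untested is made for them only; others in the source may bear on it.

Measured in an in vivo ADME assay on the whole organism (plasma) for pharmacokinetics, with Canis familiaris (Canis lupus familiaris) as the target; a lower number here means slower removal, a higher number faster removal of the compound:
compound 1 `NC1CCN(C(=O)c2ccc3[nH]c(-c4cc5ccccc5nc4O)cc3c2)C1`: 26 mL/min/kg
compound 2 `CN1CCN(S(=O)(=O)c2ccc3[nH]c(-c4cc5ccccc5nc4O)cc3c2)CC1`: 0.5 mL/min/kg

Of these two, compound 2 holds the lower number in this assay. Compound 3 `NC1CCN(S(=O)(=O)c2ccc3[nH]c(-c4cc5ccccc5nc4O)cc3c2)C1` is still unmeasured and carries 3-aminopyrrolidin-1-yl in place of 4-methylpiperazin-1-yl on a sulfonyl sulfur. Going by the values given here, only one measured step bears on this change: a 52-fold lower number from compound 1 to compound 2 (1.72 log units; beyond the scatter), a large step. That step exchanged (3-aminopyrrolidin-1-yl)carbonyl for (4-methylpiperazin-1-yl)sulfonyl, so the data do not separate the contribution of the carbonyl-to-sulfonyl exchange from that of the ring exchange. Compound 3 shares its sulfonyl with compound 2 and its 3-aminopyrrolidin-1-yl with compound 1 at 26 mL/min/kg, so part of the large step is expected to be undone. A rise beyond the scatter is expected, estimated as a 12-fold higher number from compound 2 to compound 3 (1.08 log units; beyond the scatter). For compound 3 the expected clearance is 6 mL/min/kg, with an estimated range of 1.5 mL/min/kg to 25 mL/min/kg.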

Compound 3, clearance: 11 mL/min/kg
Beside the measured number, compound 3's estimate is 1.8-fold (0.26 log units) below it, and the stated range covers the measured number.
By their numbers in this assay, from the lowest: compound 2; then compound 3; then compound 1.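

In this assay the sulfonyl is now held constant, and 3-aminopyrrolidin-1-yl in place of 4-methylpiperazin-1-yl on the sulfonyl sulfur alone gives a 22-fold higher number from compound 2 to compound 3 (1.34 log units; beyond the scatter) as a large change. With 3-aminopyrrolidin-1-yl held constant instead, sulfonyl in place of carbonyl on an aromatic carbon gives a 2.4-fold lower number from compound 1 to compound 3 (0.37 log units; beyond the scatter) as a modest change beyond the scatter, so the ring exchange carries the greater part of the combined a 52-fold lower number from compound 1 to compound 2 (1.72 log units; beyond the scatter) and the linker exchange a smaller but real part. Nothing available explains either step.

As far as these compounds go, whether 4-methylpiperazin-1-yl keeps a low number on a carbonyl remains open, so it is unknown whether the two exchanges simply add. Also open, from the compounds shown here alone, is which feature of the ring sets the number: a piperazine without the methyl or a morpholine on the sulfonyl sulfur would bear on this.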